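The source may report more compounds than this note shows. Statements on the series, on what has been measured and on what is new or still open speak of the compounds shown alone.

In a functional assay on NCI-H460 cells (Homo sapiens) for antiproliferative activity, read by CCK-8 assay, with a stated time of 72 h, tested at 8 uM (a higher number here means a stronger effect of the compound at the concentration tested, a lower number a weaker effect), compound 1 `Cc1ccc(Nc2nc(Cl)nc3c2ncn3Cc2ccc(C(=O)Nc3ccccc3N)cc2)cc1` gives 82.5%. Among the compounds with values here, compound 2 `Nc1ccccc1NC(=O)c1ccc(Cn2cnc3c(NCc4ccccc4)nc(Cl)nc32)cc1` gives 61.2% in this assay, and the only step between the two measured compounds, a number 21.3 percentage points lower from compound 1 to compound 2 (beyond the scatter), leaves compound 2 as the lower of the two numbers. Compound 3 `CC1CCN(c2nc(Cl)nc3c2ncn3Cc2ccc(C(=O)Nc3ccccc3N)cc2)CC1` has not yet been measured; it differs from compound 2 by 4-methylpiperidin-1-yl in place of benzylamino on an aromatic carbon. Within the data shown here, the one measured step, a number 21.3 percentage points lower from compound 1 to compound 2 (beyond the scatter), changed the group at this same position and cost a modest amount, so changing that group again is expected to move the number, but nothing measured shows in which direction a ring of this kind would go. An estimate centred near compound 2, with a wide range covering a further modest loss or a return toward compound 1, is the reasonable expectation, giving a number 6.2 percentage points lower from compound 2 to compound 3 (within the scatter). Compound 3 is therefore estimated at 55%, between 30% and 78%.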

Compound 3, a percentage reported as inhibition, at one concentration (the size of the read-out at that concentration, not a potency): 40.9%
For compound 3 the middle estimate is 14.1 percentage points above the measured one; the measured number falls inside the stated range.
By their numbers in this assay, from the lowest: compound 3; then compound 2; then compound 1.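

In this assay, the step to a non-aromatic ring gives a number 20.3 percentage points lower from compound 2 to compound 3 (beyond the scatter), so this position, on an aromatic carbon next to the ring nitrogen, responds to more than the swap from (4-methylphenyl)amino to benzylamino had revealed. Within the data shown here, measured against the (4-methylphenyl)amino group, the change gives a number 41.6 percentage points lower from compound 1 to compound 3 (beyond the scatter), and 4-methylpiperidin-1-yl, with 0 hydrogen-bond donors, is the only group of the three without an aromatic ring and without a nitrogen-bound hydrogen. No supporting evidence explains this fall.

These two features change together, so the compounds shown cannot separate them. A cyclohexylamino group would keep the nitrogen-bound hydrogen on a non-aromatic ring, whereas a benzyl(methyl)amino group would remove that hydrogen and keep the aromatic ring, and neither is among these compounds.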